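The compounds below may be only part of what the source reports. "The series", "measured", "known", "first", "only" and "open" are said of these compounds alone.

Compound 1, `Cn1ncc(Cl)c1-c1cc(C(=O)N[C@@H]2CN[C@H](CCO)C[C@H]2c2ccc(F)c(F)c2)oc1Cl`: 60 nM
Compound 2, `Cn1ncc(Cl)c1-c1cc(C(=O)N[C@@H]2CN[C@H](CCN3CCCC3)C[C@H]2c2ccc(Cl)c(Cl)c2)oc1Cl`: 1920 nM
Compound 3, `CNC(=O)C[C@@H]1C[C@@H](c2ccc(F)c(F)c2)[C@H](NC(=O)c2cc(-c3c(Cl)cnn3C)c(Cl)o2)CN1`: 50 nM

All three were tested in a functional assay on LNCaP cells (Homo sapiens) for antiproliferative activity; a lower number here means a stronger inhibitor, a higher number a weaker inhibitor. Compound 2 stands highest of the three numbers; compound 1 is nearest to it and compound 3 furthest, both well below it. Compound 4, `Cn1ncc(Cl)c1-c1cc(C(=O)N[C@@H]2CN[C@H](CC(O)CO)C[C@H]2c2ccc(Cl)c(Cl)c2)oc1Cl`, has not yet been measured; it differs from compound 2 by 1,2-dihydroxyethyl in place of (pyrrolidin-1-yl)methyl on a saturated chain carbon bound to a saturated ring carbon. Going by the values given here, the only measured step at the same place is a 1.2-fold lower number from compound 1 to compound 3 (0.08 log units; within the scatter), which lies within the scatter and exchanges two other groups. Compounds 1 and 3, which carry such groups, sit far below compound 2, but they also differ from it elsewhere, so that gap cannot be assigned to the chain alone. Compound 4 is nonetheless expected to come out well below compound 2, the estimated step being a 13-fold lower number from compound 2 to compound 4 (1.11 log units; beyond the scatter). The estimate for compound 4 in this assay is 150 nM, with a range from 40 nM to 600 nM.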

Compound 4, half-maximal inhibitory concentration: 70 nM
For compound 4 the middle estimate is 2.1-fold (0.33 log units) above the measured one; the range from low to high includes it.
By their numbers in this assay, from the lowest: compounds 3, 1 and 4 (each within the scatter of the next); then compound 2.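

With the rest of the structure unchanged, 1,2-dihydroxyethyl in place of (pyrrolidin-1-yl)methyl in this assay gives a 27-fold lower number from compound 2 to compound 4 (1.44 log units; beyond the scatter) and so shows that this position can carry a large change, which the earlier step there, a 1.2-fold lower number from compound 1 to compound 3 (0.08 log units; within the scatter) and within the scatter, did not show. The high number of compound 2 can now be tied to its chain, at least against compound 4. Nothing available explains the size of this step.

As far as these compounds go, whether it follows from losing (pyrrolidin-1-yl)methyl or from gaining 1,2-dihydroxyethyl remains open. A dimethylamino group or a carboxylic acid at the same place would help separate the two.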